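Aryl swap on the carbonyl carbon of compound 1

This account rests on a few compounds, and the source may have more. Where it says the series, first, only, none or still open, it means among the compounds named here.

Measured so far in a functional assay on MCF7 cells (Homo sapiens) for inhibition, read by sulforhodamine B assay, with a stated time of 48 h; on this read-out lower numbers stand for stronger inhibition of growth and higher numbers for weaker inhibition of growth:
compound 1 `COc1cc(-c2cc(/C=C/C(=O)c3ccc(N)cc3)[nH]n2)cc(OC)c1OC`, 5420 nM
compound 2 `COc1ccc(-c2cc(/C=C/C(=O)c3cc(OC)c(OC)c(OC)c3)[nH]n2)cc1OC`, 2500 nM
compound 3 `COc1ccc(-c2cc(/C=C/C(=O)c3ccc(N)cc3)[nH]n2)cc1`, 3840 nM

Compound 1 carries the highest of the three numbers in this assay. Compound 3 sits within the scatter of it, so nothing separates the two. Compound 2 lies beyond the scatter, at a lower number than compound 1; the two differ in more than one place, so only the values themselves can be compared.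

Compound 4 `COc1cc(-c2cc(/C=C/C(=O)c3ccc(F)c(F)c3)[nH]n2)cc(OC)c1OC` is not yet measured. Against compound 1 the change is 3,4-difluorophenyl in place of 4-aminophenyl on a carbonyl carbon. Among the measured compounds shown here, no pair of measured compounds shows this exchange, and no measured compound carries a fluorine, so the step has no direct precedent here. The expectation for compound 4 is a step of a 1.4-fold lower number from compound 1 to compound 4 (0.13 log units; within the scatter) that stays within the scatter, with a slight lean toward a lower number. Compound 4 is expected at about 4000 nM, estimated between 1500 nM and 12000 nM.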

Compound 4, concentration for total growth inhibition: 12300 nM
Beside the measured number, compound 4's estimate is 3.1-fold (0.49 log units) below it; the measured number lies above the stated range.
By their numbers in this assay, from the lowest: compounds 2, 3 and 1 (each within the scatter of the next, the first and the last beyond it); then compound 4.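

In this assay, the only exchange shown at this carbonyl carbon gives a 2.3-fold higher number from compound 1 to compound 4 (0.36 log units; beyond the scatter), so the aryl group here is not neutral for this read-out, with 3,4-difluorophenyl doing worse than 4-aminophenyl. The leaving group carries a hydrogen-bond donor and acceptor and the entering group neither, but this single step cannot separate that difference from the arrival of fluorine. Nothing measured here accounts for the step.

Open, as far as these compounds go, is whether a hydroxyl or a dimethylamino group on this aryl would stay near compound 1 or compound 4. Also open, from the compounds shown here alone, is whether the same exchange on compound 3 gives a similar step.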